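Moving the methyl on the carboxyphenyl ring of compound 3

A few compounds are considered here, and "the series" means these few. Any claim that something is new, unique, unknown or untested is made for them only; others in the source may bear on it.

In an assay on HEK293 cells for positive allosteric modulation of metabotropic glutamate receptor 3 (Rattus norvegicus), read by thallium flux, with a stated time of 2.5 min (a lower number here means a smaller maximal response, a higher number a larger maximal response), compound 1 `Cc1c(OCCCCOc2ccc(F)c(C(=O)O)c2)ccc(C(=O)CC2CCCC2)c1O` gives 98.4%, compound 2 `Cc1cc(OCCCCOc2ccc(C(=O)CC3CCCC3)c(O)c2C)ccc1C(=O)O` gives 23.7% and compound 3 `Cc1c(OCCCCOc2ccc(C(=O)O)c(Cl)c2)ccc(C(=O)CC2CCCC2)c1O` gives 40%. Compound 3 therefore stands second highest of the three numbers: it lies a number 16.3 percentage points higher from compound 2 to compound 3 (beyond the scatter) and a number 58.4 percentage points lower from compound 1 to compound 3 (beyond the scatter). Compound 4 `Cc1cc(C(=O)O)ccc1OCCCCOc1ccc(C(=O)CC2CCCC2)c(O)c1C` differs from compound 3 in one place: 4-carboxy-2-methylphenyl in place of 4-carboxy-3-chlorophenyl on an oxygen on a saturated carbon. The step that bears most directly on this change is the swap of chloro for methyl on an aromatic carbon, which gave a number 16.3 percentage points higher from compound 2 to compound 3 (beyond the scatter); compound 4 reverses that swap, though the methyl now sits on a different carbon of the carboxyphenyl ring. The steps from compound 1 also show that every carboxyphenyl variant measured so far responds far less than compound 1, as in a number 74.7 percentage points lower from compound 1 to compound 2 (beyond the scatter). A modest downward step is therefore expected for compound 4, roughly a number 10 percentage points lower from compound 3 to compound 4 (within the scatter). Compound 4 is estimated at 30% in this assay, within a range of 15% to 55%.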

Compound 4, largest response reached (reported as percent of maximum), in percent of the reference or control that the assay uses: 28.4%
For compound 4 the middle estimate is 1.6 percentage points above the measured one; low and high end bracket the measured number.
By their numbers in this assay, from the lowest: compounds 2 and 4 (each within the scatter of the next); then compound 3; then compound 1.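

In this assay, the 4-carboxy-2-methylphenyl group of compound 4 and the 4-carboxy-3-methylphenyl group of compound 2 cannot be told apart, with a number 4.7 percentage points higher from compound 2 to compound 4 (within the scatter), so these two placements of the methyl read alike. Against the 4-carboxy-3-chlorophenyl group, the 4-carboxy-2-methylphenyl group gives a number 11.6 percentage points lower from compound 3 to compound 4 (beyond the scatter), a modest step. The 3-carboxy-4-fluorophenyl group remains far removed from this new variant, with a number 70 percentage points lower from compound 1 to compound 4 (beyond the scatter), so all three 4-carboxyphenyl groups shown fall well short of it.

Nothing shown gives a reason for these differences. Also open, on these data alone, is whether the placement of the carboxy group or the fluoro drives the high response of compound 1, and how a tetrazole in place of the carboxy group would behave.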